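The source may report more compounds than this note shows. Statements on the series, on what has been measured and on what is new or still open speak of the compounds shown alone.

Compound 1 `C#CCNC1CCc2c(SCCc3cccc(C)c3)cccc21`: 4960 nM
Compound 2 `C#CCNC1CCc2c(SCCc3cccc(C(F)(F)F)c3)cccc21`: 280 nM
Compound 3 `C#CCNC1CCc2c(SCc3ccc(C(F)(F)F)cc3)cccc21`: 930 nM

These three compounds were measured in an ADME assay on isolated protein for inhibition of Amine oxidase [flavin-containing] B (Homo sapiens); a lower number here means a stronger inhibitor, a higher number a weaker inhibitor. Compound 2 and compound 1 differ in one place, (methyl in place of trifluoromethyl on an aromatic carbon), and that change gave an 18-fold higher number from compound 2 to compound 1 (1.25 log units; beyond the scatter). Compound 3 carries the same trifluoromethyl group as compound 2, but the difference between the two cores is not broken down here. Compound 4 `C#CCNC1CCc2c(SCc3ccc(C)cc3)cccc21` has not been measured in this assay. It differs from compound 3 by methyl in place of trifluoromethyl on an aromatic carbon. This is the same kind of change as that made between compound 2 and compound 1, though not the same: in compound 3 the group sits para to a large group, whereas in compound 2 it sits meta to a large group. The expectation rests on the large step of an 18-fold higher number from compound 2 to compound 1 (1.25 log units; beyond the scatter) seen with that earlier pair. Compound 4 is therefore expected to show a step of about a 9.7-fold higher number from compound 3 to compound 4 (0.99 log units; beyond the scatter). Compound 4 is estimated at 9000 nM, within 3000 nM to 30000 nM.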

Compound 4, half-maximal inhibitory concentration: 320 nM
Estimate against measurement, compound 4: 28-fold (1.45 log units) above, and the stated range ends above it.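

In this assay, methyl in place of trifluoromethyl gave a 2.9-fold lower number from compound 3 to compound 4 (0.46 log units; beyond the scatter), whereas the same change on the other core gave an 18-fold higher number from compound 2 to compound 1 (1.25 log units; beyond the scatter). Within the data shown here, the effect of this change therefore did not carry from one core to the other, in size or in direction: the same change on two cores in this assay, an 18-fold higher number (1.25 log units; beyond the scatter) from compound 2 to compound 1 and a 2.9-fold lower number (0.46 log units; beyond the scatter) from compound 3 to compound 4, 51-fold (1.71 log units) apart, beyond the scatter of two such steps This shows that a step measured on one core cannot be assumed on the other, but with only two pairs it does not show which feature of the cores governs the outcome.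

From the compounds shown here alone, it remains open how other groups in the same place, such as chlorine or methoxy, would behave on each core. Going by these compounds, it is also open which of the two steps a core with a longer chain would follow.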